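A few compounds are considered here, and "the series" means these few. Any claim that something is new, unique, unknown or untested is made for them only; others in the source may bear on it.

In a functional assay on SH-SY5Y cells (Homo sapiens) for antiproliferative activity, read by MTT assay, with a stated time of 48 h (on this read-out lower numbers stand for stronger inhibition of growth and higher numbers for weaker inhibition of growth), compound 1 `COc1ccccc1OCCNc1ccc(=O)n(Cc2ccc(OC)c(OC3CCCC3)c2)n1` gives > 100000 nM, which is a limit of the assay and not a number. Its close relative, compound 2 `COc1ccccc1OCCNc1ccc(=O)n(Cc2ccc(OC(F)F)c(OC3CCCC3)c2)n1`, gives a measured 9300 nM. This is an at least 10-fold lower number from compound 1 to compound 2 (1.03 log units; beyond the scatter), a large step beyond the scatter, made by placing difluoromethyl in place of methyl on an oxygen on an aromatic ring. Compound 3 `COc1ccccc1OCCNc1ccc(=O)n(Cc2ccc(OC)c(OCC3CC3)c2)n1` keeps that methyl and is changed elsewhere: cyclopropylmethyl in place of cyclopentyl on an oxygen on an aromatic ring. Cyclopropylmethyl stands in place of cyclopentyl on an oxygen on an aromatic ring. Within the data shown here, no measured step covers this change, so the large step seen with compound 2 offers only a weak guide. Only a small shift towards a lower number is expected, and compound 3 may stay at the limit. The expected change is an at least 1.4-fold lower number from compound 1 to compound 3 (0.15 log units; that floor lies within the scatter). For compound 3 the estimated value is 70000 nM, with an expected range of 20000 nM to 100000 nM.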

Compound 3, concentration for 50% growth inhibition: 10500 nM
Estimate against measurement, compound 3: 6.7-fold (0.82 log units) above; measured number outside the range, below it.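

In this assay, the group on this oxygen clearly matters: cyclopropylmethyl in place of cyclopentyl gives an at least 9.5-fold lower number from compound 1 to compound 3 (0.97 log units; beyond the scatter). The earlier step came from replacing the methyl, so compound 3 shows that a change at the cyclopentyl place can also turn compound 1 into a compound with a measured value. The starting point of this step, compound 1, is a limit and not a number, so the step gives only a floor and not its full size: the limit of > 100000 nM in this assay, at which 1 of the 3 values shown sits.

The compounds shown do not tell whether the three-membered ring itself counts or some other difference between the two groups, a question that a straight butyl chain or a cyclobutyl group on the same oxygen could help to settle. They also leave open whether difluoromethyl and cyclopropylmethyl together in one compound would lower the number further.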